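A few compounds are considered here, and "the series" means these few. Any claim that something is new, unique, unknown or untested is made for them only; others in the source may bear on it.

The series shares one core, seen in compound 1 `COC(=O)c1ccc(NCc2cncn2Cc2ccc(C(C)(C)C)cc2)cc1-c1ccccc1` and in compound 2 `O=C(OC1CCCCC1)c1ccc(NCc2cncn2Cc2ccc(-c3ccccc3)cc2)cc1-c1ccccc1`. In a toxicity assay on NIH3T3 cells (Mus musculus) for cytotoxicity, read by resazurin assay (a higher number here means that more compound is needed for the effect, a lower number that less compound is needed), compound 1 gives "not determined" (no result reported), so no number places it on the scale. Compound 2 reaches only a limit of the assay in this assay, where it gives > 10000 nM. Within the data shown here, that is the only value shown, and it sits at the limit described by the limit of > 10000 nM in this assay, at which 1 of the 2 values shown sits. Compound 3 `COC(=O)c1ccc(NCc2cncn2Cc2ccccc2Br)cc1-c1ccccc1` has not yet been measured in this assay. It differs from compound 1 by 2-bromophenyl in place of 4-(tert-butyl)phenyl on a saturated chain carbon bound to an aromatic nitrogen. Among the measured compounds shown here, no measured step between any two compounds exists in this assay, so nothing here tells how this change moves the read-out; with the single value at a limit, a step in either direction cannot be sized, and none beyond the scatter is assumed. Compound 3 is expected to give about 15000 nM in this assay, within 4000 nM to 60000 nM, most likely again as a limit.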

Compound 3, half-maximal effective concentration: 10000 nM
For compound 3 the middle estimate is 1.5-fold (0.18 log units) above the measured one, within the range that was stated.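

Among these compounds, with compound 1 giving "not determined" (no result reported) in this assay, no step to compound 3 can be read. The compounds shown leave open how 2-bromophenyl in place of 4-(tert-butyl)phenyl moves the read-out, and whether any single change on the shared core does so beyond the usual scatter.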